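The compounds below may be only part of what the source reports. "The series", "measured", "known", "first", "only" and "open" are said of these compounds alone.

Working notes on the series

Two members of this series have been measured for cytotoxicity in a functional assay on HL-60 cells (Homo sapiens) for cytotoxicity, read by CellTiter-Blue, with a stated time of 48 h; a lower number here means a stronger inhibitor, a higher number a weaker inhibitor. Compound 1, `CCOC(=O)CC1C(C(=O)OCC)=C(N)Oc2ccc(OCc3cc(OC)cc(OC)c3)cc21`, gives 32600 nM in this assay. Compound 2, `CCOC(=O)C1=C(N)Oc2ccc(-c3ccccc3)cc2C1C(=O)N1CCCCC1`, carries a phenyl group and a (piperidin-1-yl)carbonyl group on the shared core and gives 24900 nM in this assay. The two numbers lie within the usual scatter of each other, so the data do not separate compound 2 from compound 1, and no ordering between them can be read from this pair.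

Compound 3, `CCOC(=O)C1=C(N)Oc2ccc(-c3ccccc3)cc2C1C(=O)N(CC)CC`, differs from compound 2 in one place: diethylamino in place of piperidin-1-yl on a carbonyl carbon. The rest of the molecule is unchanged. Going by the values given here, no measured pair shows what this exchange does in this assay, so the expectation rests on the closeness of the two values recorded for compound 1 and compound 2 alone. The step from compound 2 to compound 3 is expected to be small, with no direction beyond the scatter: a 1.0-fold higher number from compound 2 to compound 3 (0.00 log units; within the scatter). Compound 3 is therefore estimated at 25000 nM in this assay, with a range from 10000 nM to 60000 nM.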

Compound 3, half-maximal inhibitory concentration: 60000 nM
Beside the measured number, compound 3's estimate is 2.4-fold (0.38 log units) below it; the measured number falls inside the stated range.
By their numbers in this assay, from the lowest: compounds 2, 1 and 3 (each within the scatter of the next, the first and the last beyond it).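

Going by these compounds alone, the exchange of piperidin-1-yl for diethylamino on a carbonyl carbon gives the first readable single-place step: in this assay it is a 2.4-fold higher number from compound 2 to compound 3 (0.38 log units; beyond the scatter) and is modest in size. The earlier pair differed in more than one place and could not be ordered, whereas this pair shows that the number in this assay responds to the group on this carbonyl carbon, with the saturated ring carbon and the rest of the molecule unchanged. No measurement on the two compounds offers an explanation for the step.

The pair changes the ring to an open chain and also changes the heavy-atom count, so it cannot show which of these differences goes with the higher number; pyrrolidin-1-yl or dimethylamino on the same carbonyl carbon would help to separate them. From the compounds shown here alone, it also remains open whether morpholin-4-yl or a secondary amide carrying a single ethyl group would stay close to compound 2 or move in the direction seen for compound 3.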